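Swapping bromo for a hydroxymethyl-bearing ring

This account rests on a few compounds, and the source may have more. Where it says the series, first, only, none or still open, it means among the compounds named here.

Of the compounds shown here, three sharing one core have been measured in a physicochemical assay for lipophilicity, read by HPLC, at pH 7.5; a lower number here means a more polar compound, a higher number a more lipophilic compound. Compound 3 (`CC[C@@H](Nc1c(C#N)c(-c2ccc(Br)cc2)nc2cnccc12)C(N)=O`) gives 2.2, compound 2 (`CC[C@@H](Nc1c(C#N)c(-c2ccc(-c3cccc(CO)c3)cc2)nc2cnccc12)C(N)=O`) gives 2, and compound 1 (`CC[C@@H](Nc1c(C#N)c(-c2ccc(-c3ccccc3N(C)C)cc2)nc2cnccc12)C(N)=O`) gives 3.2. Compound 3 and compound 2 thus lie within the scatter of each other, while compound 1 stands clearly higher than both.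

Compound 4 (`CC[C@@H](Nc1c(C#N)c(-c2ccc(-c3ccccc3CO)cc2)nc2cnccc12)C(N)=O`) has 2-(hydroxymethyl)phenyl in place of the bromo of compound 3, on an aromatic carbon para to a large group: 2-(hydroxymethyl)phenyl in place of bromo on an aromatic carbon.

The closest evidence is the measured swap between 3-(hydroxymethyl)phenyl and bromo, a number 0.20 log units higher from compound 2 to compound 3 (within the scatter). The bigger steps, a number 1.20 log units lower from compound 1 to compound 2 (beyond the scatter) and a number 1.00 log units lower from compound 1 to compound 3 (beyond the scatter), both start from the 2-(dimethylamino)phenyl group, which compound 4 does not carry. No shift beyond the scatter is therefore expected in this assay, and the estimated change is a number 0.10 log units lower from compound 3 to compound 4 (within the scatter). For compound 4 the estimated value is 2.1, expected to fall between 1.7 and 2.5.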

Compound 4, distribution coefficient: 2.1
Compound 4: middle estimate and measured number agree at the digits printed, and the stated range covers the measured number.
By their numbers in this assay, from the lowest: compounds 2, 4 and 3 (each within the scatter of the next); then compound 1.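

In this assay, the hydroxymethyl group on 2-(hydroxymethyl)phenyl and on 3-(hydroxymethyl)phenyl cannot be told apart, with the printed step (a number 0.10 log units higher from compound 2 to compound 4 (within the scatter)) staying small. Compound 4 also stays close to the bromo compound (a number 0.10 log units lower from compound 3 to compound 4 (within the scatter)), so adding this whole ring in place of bromo leaves the number almost where it was. The clear shift (a number 1.10 log units lower from compound 1 to compound 4 (beyond the scatter)) now comes from a pair that differs only by hydroxymethyl in place of dimethylamino, so the earlier gap between compound 1 and compound 2 need not depend on where the group sits on the ring.

Still open, from the compounds shown here alone, is where 3-(dimethylamino)phenyl, or a ring carrying a carboxylic acid, would fall in this assay. Nothing given here explains why dimethylamino and hydroxymethyl differ so clearly.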